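The source may report more compounds than this note shows. Statements on the series, on what has been measured and on what is new or still open speak of the compounds shown alone.

Measured compounds in a functional assay on SW480 cells (Homo sapiens) for cytotoxicity, read by MTT assay, with a stated time of 4 days; on this read-out higher numbers stand for weaker inhibition and lower numbers for stronger inhibition:

Compound 1 `Cc1c(O)ccc2c1[C@H](Cn1cc(-c3ccc(F)cc3)nn1)[C@@]13CC(=O)[C@@](C)(CC[C@@H]21)C3`. In this assay compound 1 gives > 20000 nM, a limit of the assay rather than a number.

Compound 2 `C=C1C[C@]23C[C@@]1(O)CC[C@@H]2c1cccc(C)c1[C@@H]3Cn1cc(-c2ccc(OC)cc2)nn1`. In this assay compound 2 gives > 20000 nM, again a limit of the assay.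

Compound 3 `C=C1C[C@]23C[C@@]1(O)CC[C@@H]2c1cccc(C)c1[C@@H]3Cn1cc(-c2ccc(Cl)cc2)nn1`. In this assay compound 3 gives > 20000 nM, which is a limit of the assay and not a number.

Compound 3 therefore stands where every measured value of the series stands: at the limit described by the limit of > 20000 nM in this assay, at which 3 of the 3 values shown sit. For the measured compounds named here, the one step measured between compounds that differ in a single place, a step that the two limits leave unreadable from compound 2 to compound 3, cannot be sized, since both ends sit at that limit.

Compound 4 `C=C1C[C@]23C[C@@]1(O)CC[C@@H]2c1cccc(C)c1[C@@H]3Cn1cc(-c2ccc(Br)cc2)nn1` is the next member. Its difference from compound 3 is bromo in place of chloro on an aromatic carbon; the same difference, cut one bond further out, reads 4-chlorophenyl to 4-bromophenyl.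

Going by the values given here, no measured step bears directly on this exchange. The nearest comparison, from compound 2 to compound 3 , is unreadable, and the whole series sits at the limit. Compound 4 is expected to remain at that limit, so the expected step that the limit leaves unreadable from compound 3 to compound 4 is none beyond the scatter. The estimate for compound 4 in this assay is 30000 nM, within 15000 nM to 100000 nM.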

Compound 4, half-maximal inhibitory concentration: > 20000 nM
Compound 4 was reported as a limit (the forecaster's own chance of this, stated with the estimate: 85%); the middle value lies beyond the limit too.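

In this assay compound 4 gives > 20000 nM, a limit of the assay and not a number. For the compounds shown here, no step among compound 2, compound 3 and compound 4 can be read, since all sit at one limit: the limit of > 20000 nM in this assay, at which 4 of the 4 values shown sit. The compounds shown leave open whether methoxy, chloro and bromo differ at all in this assay.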